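The source may hold more compounds than are shown below. What is called first, only, known or untested is meant among the compounds shown, and "the series" means these compounds.

Measured compounds, with their values in an ADME assay on NIH3T3 cells (Mus musculus) for cytotoxicity, read by MTT assay, with a stated time of 24 h; on this read-out lower numbers stand for stronger inhibition and higher numbers for weaker inhibition:
compound 1 `Cn1nnnc1SCC(=O)N/N=c1/scc(-c2ccc(Br)cc2)n1-c1ccccc1`: 19.3 ug/mL
compound 2 `Cc1ccc(-c2cs/c(=N/NC(=O)CSc3nnnn3C)n2-c2ccccc2)cc1`: 243 ug/mL
compound 3 `Cn1nnnc1SCC(=O)N/N=c1/scc(-c2ccc(Cl)cc2)n1-c1ccccc1`: 40 ug/mL

Compound 1 gives the lowest number of the three; the two steps away from it are a 2.1-fold higher number from compound 1 to compound 3 (0.32 log units; beyond the scatter) and a 13-fold higher number from compound 1 to compound 2 (1.10 log units; beyond the scatter), and both changes sit on an aromatic carbon. Compound 4 `Cc1nnc(SCC(=O)N/N=c2/scc(-c3ccc(Br)cc3)n2-c2ccccc2)s1` differs from compound 1 at another place: 5-methyl-1,3,4-thiadiazol-2-yl in place of 1-methyl-1H-tetrazol-5-yl on a sulfur. Within the data shown here, no measured step touches this position, so the measured steps show only how widely the series spreads and give no direct guide to this swap. Lacking a precedent, the number for compound 4 is expected to stay near that of compound 1, with an estimated step of a 1.3-fold higher number from compound 1 to compound 4 (0.11 log units; within the scatter) that may remain within the scatter. The estimate for compound 4 in this assay is 25 ug/mL, in the range 8 ug/mL to 80 ug/mL.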

Compound 4, half-maximal inhibitory concentration: 55 ug/mL
Compound 4: middle estimate off by 2.2-fold (0.34 log units), on the low side; low and high end bracket the measured number.
By their numbers in this assay, from the lowest: compound 1; then compounds 3 and 4 (each within the scatter of the next); then compound 2.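

In this assay, the group on the sulfur also moves the number: 5-methyl-1,3,4-thiadiazol-2-yl in place of 1-methyl-1H-tetrazol-5-yl gives a 2.8-fold higher number from compound 1 to compound 4 (0.45 log units; beyond the scatter). Both groups hold 6 heavy atoms, so a shift beyond the scatter occurs here with no change in that count. Nothing available accounts for the shift.

From the compounds shown here alone, whether the same swap gives a similar step with the chloro of compound 3 or the methyl of compound 2 remains open. Also open, going by these compounds, is how an unringed group on the sulfur, such as a longer alkyl chain or a chain ending in an amine, would read.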